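The source may hold more compounds than are shown below. What is called first, only, known or untested is meant among the compounds shown, and "the series" means these compounds.

Measured so far:
compound 1 `CCN1CCC(N2CCN(c3ccccc3)CC2)C(O)C1`, > 1000 nM
compound 2 `C=CCN1CCC(N2CCN(c3ccccc3)CC2)C(O)C1`, > 100 nM
compound 3 `CCN1CCC(O)C(N2CCN(c3ccccc3)CC2)C1`, > 1000 nM

In an assay on PC-12 cells for displacement of a labelled ligand from vesicular acetylcholine transporter (Homo sapiens) (a higher number here means a weaker inhibitor, a lower number a stronger inhibitor), compound 1 gives only a limit, > 1000 nM. Compound 2 likewise gives only a limit in this assay, > 100 nM. Compound 3 also gives only a limit, > 1000 nM. Among the compounds with values here, two of the three results sit at the limit of > 1000 nM in this assay, at which 2 of the 3 values shown sit, and one at the limit of > 100 nM in this assay, at which 1 of the 3 values shown sits, so no compound here has a number in this assay.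

The change from compound 1 to compound 2 is vinyl in place of methyl on a saturated chain carbon bound to an amine nitrogen in a ring. The step that the two limits leave unreadable from compound 1 to compound 2, because the limit of > 100 nM in this assay, at which 1 of the 3 values shown sits, and the limit of > 1000 nM in this assay, at which 2 of the 3 values shown sit, bound it on both sides.

Compound 4 `C=CCN1CCC(O)C(N2CCN(c3ccccc3)CC2)C1` is not yet measured in this assay. Compound 4 differs from compound 3 by vinyl in place of methyl on a saturated chain carbon bound to an amine nitrogen in a ring, the same change that separates compound 1 and compound 2, at the same place. Compound 1 and compound 3 share their atoms in a different arrangement; the difference between the two cores is not broken down here.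

For compound 4 in this assay the expected step is a step that the limit leaves unreadable from compound 3 to compound 4, resting only on compound 3 at > 1000 nM and on the unreadable step between compound 1 and compound 2. Compound 4 is estimated at 2500 nM, between 600 nM and 10000 nM.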

Compound 4, half-maximal inhibitory concentration: > 100 nM
Compound 4: only a limit was reported (the forecaster's own chance of this, stated with the estimate: 70%); the middle value is on the limit's open side.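

In this assay, compound 3 and compound 4 both give only limits, so no step can be read between them. The compounds shown leave open whether vinyl in place of methyl changes inhibition in either core, and how strongly compound 1, compound 2, compound 3 or compound 4 actually inhibits.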